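Working notes on compound 3 and the planned compound 4

The source may hold more compounds than are shown below. What is called first, only, known or untested is meant among the compounds shown, and "the series" means these compounds.

Measured in an assay on HEK293 cells for binding affinity to Substance-K receptor (Rattus norvegicus), read by FRET, tested at 10 uM; a higher number here means more inhibition at the concentration tested (going by the name of the read-out), a lower number less inhibition:
compound 1 `N#CCN(Cc1ccc(CCc2ccccc2)cc1)Cc1ccc2ccccc2c1`: 20%
compound 2 `N#CCN(Cc1ccccc1)Cc1cccc(Cl)c1`: 0%
compound 3 `N#CCN(Cc1ccccc1)Cc1ccc(Cl)cc1`: 0%

Compound 3 stands level with compound 2 at the digits shown, and the two together are the lowest of the three numbers; compound 1 lies higher by an amount beyond the usual scatter. Among the measured compounds shown here, no two measured compounds differ in a single place, so no measured step is available to read across.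

Compound 4 `COc1ccc(CN(CC#N)Cc2ccccc2)cc1` has not yet been measured. Against compound 3 it carries methoxy in place of chloro on an aromatic carbon. For the measured compounds named here, no measured pair covers this exchange, and nothing points to a particular direction. From compound 3 to compound 4 the step expected in this assay is a number 3 percentage points higher from compound 3 to compound 4 (within the scatter), not beyond the scatter. Compound 4 is therefore estimated at 3%, with a range from 0% to 15%.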

Compound 4, a percentage reported as inhibition, at one concentration (the size of the read-out at that concentration, not a potency): 0%
The estimate for compound 4 lay 3 percentage points above the measured number; the measured number falls inside the stated range.
By their numbers in this assay, from the lowest: compounds 2, 3 and 4 (each within the scatter of the next); then compound 1.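

Methoxy in place of chloro on an aromatic carbon, para to a large group, gives the series its first single-place step: in this assay it reads no change at the digits printed from compound 3 to compound 4 (within the scatter). At this place, then, a group with one hydrogen-bond acceptor reads no differently from chloro, which has none, though neither number rises off the bottom of the read-out. No measurement on hand offers a reason for this result.

Still open, on these data alone, is whether an amine, a carboxylic acid or a longer alkoxy chain at this place would lift the number. Equally open, as far as these compounds go, is how any exchange here would read on the core of compound 1.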